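The source may hold more compounds than are shown below. What is called first, only, known or untested is meant among the compounds shown, and "the series" means these compounds.

Working notes on the series. In an assay on isolated protein for inhibition of protein deacetylase HDAC6 (Homo sapiens), read by fluorescence, with a stated time of 15 min (a lower number here means a stronger inhibitor, a higher number a weaker inhibitor), compound 1 `Nc1ccccc1NC(=O)c1ccc(-c2nnc(Cc3cccc4ccccc34)o2)cc1` gives 16100 nM, compound 2 `O=C(NO)c1ccc(-c2nnc(Cc3cccc4ccccc34)o2)cc1` gives 4100 nM, and compound 3 `O=C(/C=C/c1ccc(-c2nnc(Cc3cccc4ccccc34)o2)cc1)NO` gives 60 nM. Compound 3 thus stands lowest of the three numbers; the nearest is compound 2, with a 68-fold lower number from compound 2 to compound 3 (1.83 log units; beyond the scatter), and the furthest is compound 1, with a 270-fold lower number from compound 1 to compound 3 (2.43 log units; beyond the scatter).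

Compound 4 `Nc1ccccc1NC(=O)/C=C/c1ccc(-c2nnc(Cc3cccc4ccccc34)o2)cc1` differs from compound 3 by 2-aminophenyl in place of hydroxy on an amide-type nitrogen. For the measured compounds named here, the only measured step on the same change, run in the other direction, is a 3.9-fold lower number from compound 1 to compound 2 (0.59 log units; beyond the scatter), a modest shift. Going by the values given here, no measured step shows this swap on the ethenyl-linked core, so whether the size carries over from compound 1 and compound 2 to compound 3 and compound 4 is not known. On that basis a modest step upward in this assay is expected, with room for a larger one.

For compound 4 the estimate is 300 nM, with a range of 80 nM to 2000 nM, meaning an expected step of a 5.0-fold higher number from compound 3 to compound 4 (0.70 log units; beyond the scatter).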

Compound 4, half-maximal inhibitory concentration: > 20000 nM
Compound 4: only a limit was reported; the forecaster's own chance of this, stated with the estimate: 3%; middle value at least 66-fold (1.82 log units) away from the limit.
By their numbers in this assay, from the lowest: compound 3; then compound 2; then compound 1. At a limit, above all of these: compound 4.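

On the core of compound 3, 2-aminophenyl in place of hydroxy on an amide-type nitrogen gives a far larger rise in this assay than the matching change gives on the core of compound 1, with an at least 330-fold higher number from compound 3 to compound 4 (2.52 log units; beyond the scatter). The size of this change thus differs between these two cores, and the step measured on one does not carry over to the other: the same change on two cores in this assay, a 3.9-fold lower number (0.59 log units; beyond the scatter) from compound 1 to compound 2 and an at least 330-fold lower number (2.52 log units; beyond the scatter) from compound 4 to compound 3, at least 84-fold (1.92 log units) apart, beyond the scatter of two such steps. Going by these compounds, for compound 4 the reported value is only a limit, so the full size of the step stays unknown: the limit of > 20000 nM in this assay, at which 1 of the 4 values shown sits.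

Open, on these data alone, is whether a saturated ethyl chain in place of the ethenyl link would keep the number of compound 3. Also open, as far as these compounds go, is whether a carboxylic acid in place of hydroxycarbamoyl or (2-aminophenyl)carbamoyl would follow either of these two groups on the shared core.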